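Removing One Carbon from the Amide Nitrogen

This account rests on a few compounds, and the source may have more. Where it says the series, first, only, none or still open, it means among the compounds named here.

Two compounds have been examined in an assay on microsomes from liver for inhibition of 3-hydroxy-3-methylglutaryl-coenzyme A reductase (Rattus norvegicus); on this read-out lower numbers stand for stronger inhibition and higher numbers for weaker inhibition. Compound 1, `CC(C)c1c(C(=O)N(C)Cc2ccccc2)nn(-c2ccc(F)cc2)c1CC[C@@H](O)C[C@@H](O)CC(=O)O`, gives 6.2 nM in this assay. Compound 2, `CCN(Cc1ccccc1)C(=O)c1nn(-c2ccc(F)cc2)c(OC[C@@H](O)C[C@@H](O)CC(=O)O)c1C(C)C`, gives 14 nM in this assay, the higher of the two numbers; compound 1 sits at the lower number, and the gap between them lies beyond the usual scatter. The next compound, compound 3, `CC(C)c1c(C(=O)N(C)Cc2ccccc2)nn(-c2ccc(F)cc2)c1OC[C@@H](O)C[C@@H](O)CC(=O)O`, is compound 2 with one change: hydrogen in place of methyl on a saturated chain carbon bound to an amide-type nitrogen. Within the data shown here, no pair measured so far differs by this change alone, so its effect is unknown here. Since compound 1, which carries the same benzyl(methyl)carbamoyl group and gives 6.2 nM, and compound 2, which gives 14 nM, are separated by only a modest gap, the step of a 1.4-fold lower number from compound 2 to compound 3 (0.15 log units; within the scatter) is expected to be small, if anything toward a lower number. Compound 3 is therefore estimated at 10 nM, within a range from 4 nM to 25 nM.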

Compound 3, half-maximal inhibitory concentration: 5.2 nM
The estimate for compound 3 lay 1.9-fold (0.28 log units) above the measured number; the range from low to high includes it.
By their numbers in this assay, from the lowest: compounds 3 and 1 (each within the scatter of the next); then compound 2.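

In this assay, trimming benzyl(ethyl)carbamoyl to benzyl(methyl)carbamoyl gives a 2.7-fold lower number from compound 2 to compound 3 (0.43 log units; beyond the scatter), so at this position a single carbon on the amide-type nitrogen changes the number by more than the usual scatter. With the benzyl(methyl)carbamoyl group held constant, placing (5-carboxy-2,4-dihydroxypentyl)oxy in place of 6-carboxy-3,5-dihydroxyhexyl on an aromatic carbon gives a 1.2-fold lower number from compound 1 to compound 3 (0.08 log units; within the scatter), so this assay does not separate these two chains. No measurement shown here offers a reason for the effect of the single carbon.

The compounds shown leave open how a propyl group or a plain hydrogen on this nitrogen would read. They also leave open whether the step from ethyl to methyl would hold on the 6-carboxy-3,5-dihydroxyhexyl chain, where only the methyl form appears.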